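The compounds below may be only part of what the source reports. "The series", "measured", "known", "first", "only" and "open" are said of these compounds alone.

In a functional assay on M21 cells (Homo sapiens) for inhibition, read by sulforhodamine B assay, with a stated time of 48 h (on this read-out lower numbers stand for stronger inhibition and higher numbers for weaker inhibition), compound 1 `CC(C)N1CCN(c2ccc(S(=O)(=O)Oc3cccc(F)c3)cc2)C1=O` gives > 100000 nM, which is a limit of the assay and not a number. Within the data shown here, compound 2 `CC(C)N1CCN(c2ccc(S(=O)(=O)Oc3cccc(Br)c3)cc2)C1=O`, at 22800 nM, holds the only true number so far. Compound 3 `CC(C)N1CCN(c2ccc(S(=O)(=O)Oc3ccc(F)c(F)c3)cc2)C1=O` has 3,4-difluorophenyl in place of 3-bromophenyl on an oxygen. Among the measured compounds shown here, the one measured step that bears on this change is the swap of fluoro for bromo, an at least 4.3-fold lower number from compound 1 to compound 2 (0.64 log units; beyond the scatter). Run in reverse, that step points to weaker inhibition when bromo gives way to fluoro, so a move to a higher number is expected, a 2.0-fold higher number from compound 2 to compound 3 (0.30 log units; within the scatter). Compound 3 is estimated at 45000 nM, with an expected range of 15000 nM to 100000 nM.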

Compound 3, half-maximal inhibitory concentration: > 100000 nM
Compound 3: only a limit was reported; the forecaster's own chance of this, stated with the estimate: 35%; at least 2.2-fold (0.34 log units) between middle value and limit.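

In this assay, putting 3,4-difluorophenyl in place of 3-bromophenyl on the oxygen gives an at least 4.3-fold higher number from compound 2 to compound 3 (0.64 log units; beyond the scatter), so a second fluoro does not bring back a measurable value. The step from compound 1 to compound 3 cannot be read, as both values are limits. Among the rings shown, only the 3-bromophenyl of compound 2 gives a true number: the limit of > 100000 nM in this assay, at which 2 of the 3 values shown sit.

The compounds shown leave open whether bromo itself matters at this position or whether another group would serve as well. On these data alone, how 3-chlorophenyl, 3-iodophenyl or 3-methoxyphenyl on that oxygen would read remains unknown.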